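Compound 2 to compound 3: methyl replaced by hydrogen

This account rests on a few compounds, and the source may have more. Where it says the series, first, only, none or still open, it means among the compounds named here.

Measured in an ADME assay on CHO cells (Cricetulus griseus) for cytotoxicity, read by MTT assay; on this read-out higher numbers stand for weaker inhibition and lower numbers for stronger inhibition
compound 1 `COc1ccc(CCCc2ccc(CN3CCCCC3)c(O)c2)cc1` gives 69800 nM; 211000 nM (2 entries)
compound 2 `Cc1ccc(CCCc2ccc(CN3CCCCC3)c(O)c2)cc1` gives 4950 nM

In this assay, among the compounds with values here, compound 2 has 4950 nM as its only number, and one further entry gives no single number. That value lies lower than both entries of compound 1, whose own spread is wide (the several entries of compound 1 in this assay, 69800 nM; 211000 nM (2 entries)). Compound 3 `Oc1cc(CCCc2ccccc2)ccc1CN1CCCCC1` has not been measured yet. It carries hydrogen in place of methyl on an aromatic carbon. Within the data shown here, no measured pair isolates this change, so the expectation rests on compound 2 and on compound 1 at 69800 nM; 211000 nM (2 entries) on the higher side. The expected 2.0-fold higher number from compound 2 to compound 3 (0.31 log units; beyond the scatter) is a modest rise toward weaker inhibition, perhaps little beyond the scatter. For compound 3 the estimated value is 10000 nM in this assay, with an expected range from 3000 nM to 40000 nM for repeat measurements.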

Compound 3, half-maximal inhibitory concentration: 162000 nM
Beside the measured number, compound 3's estimate is 16-fold (1.21 log units) below it, and the stated range ends below it.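

In this assay, within the data shown here, going from 4-methylphenyl to phenyl gives a 33-fold higher number from compound 2 to compound 3 (1.51 log units; beyond the scatter), the first measured step at this position, para to a large group. The loss of one carbon here is enough to move the number far toward weaker inhibition, so this position matters strongly in this series. Compound 3 at 162000 nM lies inside the span of compound 1, which leaves compound 2 as the only one of the three with a low number, and the hydrogen and methoxy compounds together at the high end: the several entries of compound 1 in this assay, 69800 nM; 211000 nM (2 entries)

On these data alone, what an ethyl group, a chlorine atom or a trifluoromethyl group would give on this carbon stays open, so it is unclear whether the low number is particular to methyl. The low end also rests on one number from compound 2, whose further entry gives no single value.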